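Sulfonyl aryl swap on two quinoline cores, mGlu5 displacement

A few compounds are considered here, and "the series" means these few. Any claim that something is new, unique, unknown or untested is made for them only; others in the source may bear on it.

Measured compounds:
compound 1 `CC1CCN(c2c(S(=O)(=O)c3cc(Cl)cc(Cl)c3)cnc3ccc(Cl)cc23)CC1` 88%
compound 2 `CC1CCN(c2c(S(=O)(=O)c3ccccc3)cnc3ccc(Cl)cc23)CC1` 59%
compound 3 `CC1CCN(c2c(S(=O)(=O)c3ccccc3)cnc3cc(F)ccc23)CC1` 87%

In an assay on isolated protein for displacement of a labelled ligand from metabotropic glutamate receptor 5 (Homo sapiens), with a stated time of 60 min, tested at 1 uM (on this read-out higher numbers stand for more inhibition at the one concentration tested (going by the name of the read-out) and lower numbers for less inhibition), compound 2 gives 59% and compound 1 gives 88%; the step of a number 29 percentage points higher from compound 2 to compound 1 (beyond the scatter) is 3,5-dichlorophenyl in place of phenyl on a sulfonyl sulfur. Compound 3 shares the sulfonyl phenyl of compound 2 but sits on a different core; how the two cores differ is not broken down here. Compound 3 gives 87%, within the scatter of compound 1.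

Compound 4 `CC1CCN(c2c(S(=O)(=O)c3cc(Cl)cc(Cl)c3)cnc3cc(F)ccc23)CC1` is not yet measured. It differs from compound 3 by 3,5-dichlorophenyl in place of phenyl on a sulfonyl sulfur, the same change as from compound 2 to compound 1, at the same place. A step as large as a number 29 percentage points higher from compound 2 to compound 1 (beyond the scatter) is not expected here, because compound 3 already gives 87% and the read-out cannot rise far above that. A small step of a number 6 percentage points higher from compound 3 to compound 4 (within the scatter) is expected. Compound 4 is estimated at 93%, between 84% and 99%.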

Compound 4, a percentage reported as inhibition, at one concentration (the size of the read-out at that concentration, not a potency): 87%
Compound 4: middle estimate off by 6 percentage points, on the high side, and the stated range covers the measured number.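

The change to 3,5-dichlorophenyl in place of phenyl on a sulfonyl sulfur does not carry over as a fixed increment, since it gives no change at the digits printed from compound 3 to compound 4 (within the scatter) on the core of compound 3. The two steps differ: the same change on two cores in this assay, a number 29 percentage points higher (beyond the scatter) from compound 2 to compound 1 and no change at the digits printed (within the scatter) from compound 3 to compound 4, 29 percentage points apart, beyond the scatter of two such steps. A gain on the core of compound 2 therefore cannot be assumed on the core of compound 3, but these data do not show which difference between the cores matters, or whether compound 3 and compound 4 would separate at other concentrations.

The compounds shown leave open whether the same contrast holds on further cores. They also leave open how a sulfonyl aryl carrying an amine or a carboxylic acid in place of the chlorines would read out.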